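A second chloro on the aryl of compound 2

A few compounds are considered here, and "the series" means these few. Any claim that something is new, unique, unknown or untested is made for them only; others in the source may bear on it.

Measured so far:
compound 1, `CC(C)c1cccc(NC(=O)N[C@@H](C)c2ccccc2)c1`: 84%
compound 2, `C[C@H](NC(=O)Nc1cccc(Cl)c1)c1ccccc1`: 99%
compound 3, `C[C@H](NC(=O)Nc1cccc(Br)c1)c1ccccc1`: 100%

In an ADME assay on the whole organism with Oryza sativa as the target, tested at 1 uM (a higher number here means a weaker effect of the compound at the concentration tested, a lower number a stronger effect), compound 2 stands second highest of the three numbers. The step of a number 1 percentage points higher from compound 2 to compound 3 (within the scatter) lies within the scatter, whereas a number 15 percentage points higher from compound 1 to compound 2 (beyond the scatter) and a number 16 percentage points higher from compound 1 to compound 3 (beyond the scatter) are modest steps beyond it. Compound 4, `C[C@H](NC(=O)Nc1cc(Cl)ccc1Cl)c1ccccc1`, differs from compound 2 by chloro in place of hydrogen on an aromatic carbon. Among the measured compounds shown here, no measured step adds a chloro in place of hydrogen, so the bearing steps are only indirect: the two halogen compounds sit near the top of the scale, and swapping one halogen for another gave nothing beyond the scatter. For compound 4 no step beyond the scatter is expected, a number 2 percentage points lower from compound 2 to compound 4 (within the scatter). Compound 4 is therefore estimated at 97%, within 88% to 100%.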

Compound 4, a percentage reported as activity, at one concentration (the size of the read-out at that concentration, not a potency): 99%
Estimate against measurement, compound 4: 2 percentage points below; measured number inside the range.
By their numbers in this assay, from the lowest: compound 1; then compounds 2, 4 and 3 (each within the scatter of the next).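

In this assay, a chloro entering in place of hydrogen, ortho to a large group and para to a chloro group, gives no change at the digits printed from compound 2 to compound 4 (within the scatter). Among the compounds shown here, earlier steps only exchanged one substituent for another, so this is the first reading of a group added to an unsubstituted aromatic carbon, and it shows nothing beyond the scatter. No experimental evidence accounts for this result.
From the compounds shown here alone, whether an amine or a carboxylic acid at this same position would lower the number remains open. So does whether a chloro here would have any effect alongside the isopropyl group of compound 1.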